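A Larger Sulfur Substituent on Compound 3

The source may hold more compounds than are shown below. What is called first, only, known or untested is meant among the compounds shown, and "the series" means these compounds.

In a functional assay on HepG2 cells (Homo sapiens) for inhibition, read by MTT assay, with a stated time of 48 h (a higher number here means a weaker inhibitor, a lower number a stronger inhibitor), compound 1 `CCSc1nnc(-c2cc(OC)c(OC)c(OC)c2)n1-c1ccc(OC)cc1` gives > 60000 nM, which is a limit of the assay. Compound 3 `CCSc1nnc(-c2cc(OC)c(OC)c(OC)c2)n1-c1ccc(N(C)C)cc1` gives > 60000 nM, likewise only a limit. Compound 2 `COc1ccc(C(=O)CSc2nnc(-c3cc(OC)c(OC)c(OC)c3)n2-c2ccc(OC)cc2)cc1` gives a true number, 18100 nM. Compound 4 `COc1cc(-c2nnc(SCc3ccc(C)cc3)n2-c2ccc(N(C)C)cc2)cc(OC)c1OC` differs from compound 3 by 4-methylphenyl in place of methyl on a saturated chain carbon bound to a sulfur. One measured step changes that same place: an at least 3.3-fold lower number from compound 1 to compound 2 (0.52 log units; beyond the scatter), with (4-methoxyphenyl)carbonyl entering for methyl. The entering group there is a different one, so compound 2 is only a loose guide. The other measured step, a step that the two limits leave unreadable from compound 1 to compound 3, gives no readable size. On that ground, a similar move towards a lower number is expected, an at least 3.0-fold lower number from compound 3 to compound 4 (0.47 log units; beyond the scatter). Compound 4 is estimated at 20000 nM, with an expected range from 8000 nM to 60000 nM.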

Compound 4, half-maximal inhibitory concentration: > 60000 nM
Compound 4 gave a limit, no number; the forecaster's own chance of this, stated with the estimate: 35%; at least 3.0-fold (0.47 log units) between middle value and limit.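

Within the data shown here, compound 3 and compound 4 both stand at a limit of the assay, so no step between them can be read: the limit of > 60000 nM in this assay, at which 3 of the 4 values shown sit.
Going by these compounds, whether 4-methylphenyl in place of methyl changes the activity of compound 3 at all remains open.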